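The source may hold more compounds than are shown below. What is called first, only, known or untested is meant among the compounds shown, and "the series" means these compounds.

Measured so far:
compound 1 `Nc1ccccc1NC(=O)c1ccc(CSC(=S)N2CCN(C(c3ccccc3)c3ccccc3)CC2)cc1`: 9.9%
compound 2 `Nc1ccccc1NC(=O)c1ccc(CSC(=S)N2CCc3ccccc32)cc1`: 87%

In a functional assay on MGC-803 cells (Homo sapiens) for antiproliferative activity, read by CCK-8 assay, with a stated time of 72 h, tested at 8 uM (a higher number here means a stronger effect of the compound at the concentration tested, a lower number a weaker effect), compound 2 gives 87%, the higher of the two numbers; compound 1 gives 9.9%, a gap beyond the scatter. Compound 3 `CCN(Cc1ccncc1)C(=S)SCc1ccc(C(=O)Nc2ccccc2N)cc1` is not yet measured and differs from compound 2 in one place: ethyl((pyridin-4-yl)methyl)amino in place of 2,3-dihydro-1H-indol-1-yl on a thiocarbonyl carbon. Among the measured compounds shown here, no measured pair isolates this change. A downward step in this assay beyond the scatter is expected, since the only other amine on that thiocarbonyl carbon, in compound 1, gives 9.9%. Compound 3 is estimated at 45%, within 10% to 85%. This estimate means a step of a number 42 percentage points lower from compound 2 to compound 3 (beyond the scatter).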

Compound 3, a percentage reported as inhibition, at one concentration (the size of the read-out at that concentration, not a potency): 85.2%
Beside the measured number, compound 3's estimate is 40.2 percentage points below it; measured number above the stated range.
By their numbers in this assay, from the lowest: compound 1; then compounds 3 and 2 (each within the scatter of the next).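

In this assay, the thiocarbonyl carbon accepts an open-chain amine: ethyl((pyridin-4-yl)methyl)amino in place of 2,3-dihydro-1H-indol-1-yl gives a small change (a number 1.8 percentage points lower from compound 2 to compound 3 (within the scatter)). The five-membered non-aromatic ring of compound 2 is therefore not needed for the effect at the concentration tested, and a ring nitrogen in the aromatic ring is accepted. Nothing measured here bears on why these two amines match.

Open, going by these compounds, is whether benzyl(ethyl)amino, with a plain phenyl ring in place of the pyridine, matches compound 3. Also open, on these data alone, is whether a small dimethylamino group on the thiocarbonyl carbon holds the effect.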